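Replacing the fluorophenyl arm of compound 3

The source may report more compounds than this note shows. Statements on the series, on what has been measured and on what is new or still open speak of the compounds shown alone.

Compound 1 `CC(C)(C)NC(=O)CCc1cccc2c1B(O)OC2`: in a functional assay on HCT-116 cells (Homo sapiens) for antiproliferative activity, read by MTT assay, with a stated time of 72 h (on this read-out higher numbers stand for weaker inhibition and lower numbers for stronger inhibition), compound 1 gives > 100000 nM, which is a limit rather than a number.
Compound 2 `O=C(CCc1cccc2c1B(O)OC2)Nc1ccc(I)cc1`: in this assay compound 2 gives 50000 nM.
Compound 3 `O=C(CCc1cccc2c1B(O)OC2)Nc1cccc(-c2ccc(F)cc2)c1`: in this assay compound 3 gives 550 nM.

Among the two numbers shown, compound 3 gives the lowest. The other value shown is one that sits at the limit of > 100000 nM in this assay, at which 1 of the 3 values shown sits. Going by the values given here, the only measured step, an at least 2.0-fold lower number from compound 1 to compound 2 (0.30 log units; that floor lies within the scatter), changes the group on the amide-type nitrogen and therefore does not bear on a change at an aromatic carbon. Compound 4 `CC(=O)c1cccc(-c2cccc(NC(=O)CCc3cccc4c3B(O)OC4)c2)c1` differs from compound 3 by 3-acetylphenyl in place of 4-fluorophenyl on an aromatic carbon. Among the compounds with values here, with no measured step at this position to guide it, compound 4 is expected to give about 600 nM, between 200 nM and 2000 nM. That estimate means a step of a 1.1-fold higher number from compound 3 to compound 4 (0.04 log units; within the scatter), expected to stay within the scatter.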

Compound 4, half-maximal inhibitory concentration: 86 nM
Compound 4: middle estimate off by 7.0-fold (0.84 log units), on the high side; measured number below the stated range.
By their numbers in this assay, from the lowest: compound 4; then compound 3; then compound 2. At a limit, above all of these: compound 1.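

In this assay, going by these compounds alone, 3-acetylphenyl in place of 4-fluorophenyl gives a 6.4-fold lower number from compound 3 to compound 4 (0.81 log units; beyond the scatter), the first measured change on this aromatic carbon, and it shows that the group held here can shift the number beyond the scatter. The entering ring carries one hydrogen-bond acceptor and the leaving ring none, yet this single step cannot tie the change to that difference. Nothing measured here accounts for the change.

The compounds shown leave open whether the acetyl itself matters. An amine or a carboxylic acid in its place could test that.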